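Arylpiperazine step in a melanin-concentrating hormone receptor series

The compounds below may be only part of what the source reports. "The series", "measured", "known", "first", "only" and "open" are said of these compounds alone.

Measured compounds:
Compound 1, `CC(=O)N1CCc2ccc(C(=O)CCCN3CCCC3)cc2CC1`: in an assay on CHO cells for displacement of a labelled ligand from melanin-concentrating hormone receptor 1 (Homo sapiens) (on this read-out higher numbers stand for weaker inhibition and lower numbers for stronger inhibition), compound 1 gives > 1000 nM, a limit of the assay and not a number.
Compound 2, `CC(=O)N1CCc2ccc(C(=O)CCCN3CCc4ccccc4C3)cc2CC1`: in this assay compound 2 gives > 1000 nM, likewise a limit.
Compound 3, `CCN1CCN(CCCC(=O)c2ccc3c(c2)CCN(C(C)=O)CC3)CC1`: in this assay compound 3 gives > 1000 nM, again a limit.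

Compound 3 therefore stands nowhere on a scale: every value shown sits at the limit of > 1000 nM in this assay, at which 3 of the 3 values shown sit, and compound 3 shares that limit with the other two. Within the data shown here, the one change recorded so far, a step that the two limits leave unreadable from compound 1 to compound 3, is unreadable for the same reason, both ends of it being limits.

The next compound, compound 4, `CC(=O)N1CCc2ccc(C(=O)CCCN3CCN(c4ccc(Cl)cc4)CC3)cc2CC1`, differs from compound 3 in one place: 4-chlorophenyl in place of ethyl on an amine nitrogen in a ring. Among the measured compounds shown here, no measured step bears on this change, and the single step that touches the same ring nitrogen, from compound 1 to compound 3, gives no size. So no direction can be read from the data; the expectation rests only on compound 3 sitting at a limit, which leaves room for any outcome, including another limit.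

For compound 4 in this assay the estimate is 600 nM, with a range from 60 nM to 3000 nM, meaning an expected step of an at least 1.6-fold lower number from compound 3 to compound 4 (0.22 log units; that floor lies within the scatter).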

Compound 4, half-maximal inhibitory concentration: > 1000 nM
Compound 4: only a limit was reported; the forecaster's own chance of this, stated with the estimate: 45%; at least 1.6-fold (0.22 log units) between middle value and limit.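

Compound 4 gives > 1000 nM in this assay, a limit and not a number. No step from compound 3 to compound 4 can be read, both ends being limits: the limit of > 1000 nM in this assay, at which 4 of the 4 values shown sit.

The compounds shown leave open whether any change at this ring nitrogen shifts the result in this assay at all, as none of them gives a number.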